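Replacing 3,4-dihydroxyphenyl with 4-chlorophenyl in compound 1

The source may report more compounds than this note shows. Statements on the series, on what has been measured and on what is new or still open speak of the compounds shown alone.

Compound 1 (`O=C(CCc1nc2ccccc2c(=O)[nH]1)N/N=C/c1ccc(O)c(O)c1`) 113000000 nM
Compound 2 (`COc1cc(/C=N/NC(=O)CCCc2nc3ccccc3c(=O)[nH]2)cc(OC)c1OC`) 106000000 nM

Going by the values given here, both numbers come from a physicochemical assay, read by spectrophotometry, with a stated time of 30 min (a higher number here means a weaker inhibitor, a lower number a stronger inhibitor), and are the only measurements so far. Compound 1 stands at 113000000 nM and compound 2 at 106000000 nM within the usual scatter of each other, so the two cannot be ranked.

Compound 3 (`O=C(CCc1nc2ccccc2c(=O)[nH]1)N/N=C/c1ccc(Cl)cc1`) has not been measured. It keeps the core of compound 1 and changes in one place, on a carbon with a double bond to nitrogen, where 4-chlorophenyl takes the place of 3,4-dihydroxyphenyl. The count of that change is 4-chlorophenyl in place of 3,4-dihydroxyphenyl on a carbon with a double bond to nitrogen and it is the only difference.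

Among the compounds with values here, compounds 1 and 2 differ in more than one place, so no single-place step is available as a guide. Even so, compound 2 has no 3,4-dihydroxyphenyl group and gives 106000000 nM in the same range. On that basis, no step beyond the scatter is expected in this assay for this change, in either direction, although two values make a thin basis.

The estimated step is a 1.1-fold higher number from compound 1 to compound 3 (0.03 log units; within the scatter) and would stay within the scatter.

For compound 3 the estimated value is 120000000 nM with an expected range from 55000000 nM to 280000000 nM as its ends.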

Compound 3, half-maximal inhibitory concentration: 381000000 nM
The estimate for compound 3 lay 3.2-fold (0.50 log units) below the measured number; measured number outside the range, above it.
By their numbers in this assay, from the lowest: compounds 2 and 1 (each within the scatter of the next); then compound 3.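

In this assay, going by these compounds alone, this is the first change in a single place, and a 3.4-fold higher number from compound 1 to compound 3 (0.53 log units; beyond the scatter) shows that the group on the carbon with a double bond to nitrogen can move the number: on the core of compound 1, 4-chlorophenyl gives a weaker inhibitor than 3,4-dihydroxyphenyl. The step is modest but beyond the scatter, and it comes with a swap from a group with 2 hydrogen-bond donors and 2 hydrogen-bond acceptors to one with 0 of each, although both groups are six-membered aromatic rings of carbon only. No measurement at hand bears on why the number rises, so the step stands as an observation and not as an explanation.

Whether the rise follows the loss of the hydroxyl groups or the arrival of the chlorine stays open, as a plain phenyl ring, a ring with one hydroxyl group, and a ring carrying an amine or a carboxylic acid do not appear among the compounds shown. On these data alone, whether the same swap gives a step of similar size on the core of compound 2 is also open.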